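The source may hold more compounds than are shown below. What is called first, only, known or untested is meant among the compounds shown, and "the series" means these compounds.

Measured so far:
- compound 1 `Cn1nc(C(C)(C)C)cc1NC(=O)Nc1cc(C(F)(F)F)cc(C(F)(F)F)c1` gives 1.1 degrees C in an assay on isolated protein for inhibition of serine/threonine-protein kinase 10 (Homo sapiens), read by thermal shift assay, tested at 10 uM; on this read-out lower numbers stand for weaker stabilisation of the target and higher numbers for stronger stabilisation of the target against heat
- compound 2 `CC(C)(C)c1cc(NC(=O)Nc2ccc(Cl)cc2)n(-c2ccc(C(F)(F)F)cc2)n1` gives -0.6 degrees C in this assay

Compound 2 stands lowest of the two numbers in this assay; compound 1 lies higher, and the gap between the two values is beyond the usual scatter. These two compounds differ in more than one place, so their values are taken only as they stand, without reading a single change into the gap.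

Compound 3 `CC(C)(C)c1cc(NC(=O)Nc2ccc(Cl)cc2)n(-c2ccc(S(C)(=O)=O)cc2)n1` follows from compound 2 by one change: methylsulfonyl in place of trifluoromethyl on an aromatic carbon. Going by the values given here, no step of this kind has been measured, and compound 2 itself sits close to no shift at all in this assay. The step expected is a number 0.60 degrees C higher from compound 2 to compound 3 (within the scatter), which is to say no step beyond the scatter and in no set direction. Compound 3 is estimated at 0 degrees C in this assay, with a range from -1.5 degrees C to 1.5 degrees C.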

Compound 3, shift of the target's melting temperature: 4.1 degrees C
Estimate against measurement, compound 3: 4.1 degrees C below; the measured number lies above the stated range.
By their numbers in this assay, from the lowest: compound 2; then compound 1; then compound 3.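

In this assay, the series now has its first change in one place, and it is not a neutral one: methylsulfonyl in place of trifluoromethyl, on an aromatic carbon para to a large group, gives a number 4.7 degrees C higher from compound 2 to compound 3 (beyond the scatter) and so marks this position as sensitive to what sits on it. The two groups have the same count of heavy atoms, so the step cannot be read as a matter of that count. Nothing at hand accounts for a step of this size.

Open, on these data alone, is whether other groups here, such as an amine, a carboxylic acid or the longer ethylsulfonyl, would give a similar step. Also open, as far as these compounds go, is whether this step holds when another part of compound 2 is changed.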